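The compounds below may be only part of what the source reports. "The series", "measured", "known", "first", "only" and "open" are said of these compounds alone.

Compound 1 `COc1cc(OC)c(C(=O)c2ccccc2F)c(O)c1CN1CCCC1`: 15%; compound 2 `COc1cc(O)c(C(=O)c2ccccc2F)c(OC)c1`: 11%.

In a functional assay on THP-1 cells (Homo sapiens) for inhibition, read by ELISA, with stated times of 30 min and 24 h, tested at 1 uM (on this read-out higher numbers stand for a stronger effect at the one concentration tested and lower numbers for a weaker effect), compound 1 gives 15%, the higher of the two numbers, though the step of a number 4 percentage points lower from compound 1 to compound 2 (within the scatter) is within the scatter, so the two compounds cannot be ranked. Compound 3 `COc1cc(OC)c(C(=O)c2cccc(F)c2)c(O)c1CN1CCCC1` differs from compound 1 by 3-fluorophenyl in place of 2-fluorophenyl on a carbonyl carbon. Within the data shown here, no measured step touches the fluorophenyl part, so nothing here bears directly on this change; the one recorded step is small. No step beyond the scatter is therefore expected in this assay, in either direction. Compound 3 is estimated at 15%, between 3% and 30%, a step of no change at the digits printed from compound 1 to compound 3 (within the scatter).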

Compound 3, a percentage reported as activity, at one concentration (the size of the read-out at that concentration, not a potency): 34%
The estimate for compound 3 lay 19 percentage points below the measured number, and the stated range ends below it.
By their numbers in this assay, from the lowest: compounds 2 and 1 (each within the scatter of the next); then compound 3.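

Exchanging 2-fluorophenyl for 3-fluorophenyl on a carbonyl carbon, with the same atoms joined differently, gives a number 19 percentage points higher from compound 1 to compound 3 (beyond the scatter) in this assay. Among these compounds, this is the first step beyond the scatter, and it shows that this part of the molecule affects the read-out even when the atom count stays the same. No available evidence accounts for this step.

Going by these compounds, whether plain phenyl or chlorophenyl on this carbonyl carbon would match 3-fluorophenyl remains open. Also open, on these data alone, is whether the step persists with morpholine in place of the pyrrolidine.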